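Replacing cyclohexyl with 1-methyl-1H-pyrazol-4-yl in compound 1

The source may hold more compounds than are shown below. What is called first, only, known or untested is meant among the compounds shown, and "the series" means these compounds.

Values in an ADME assay on BaF3 cells (Mus musculus) for inhibition, read by CellTiter-Glo, with a stated time of 72 h (on this read-out higher numbers stand for weaker inhibition of growth and lower numbers for stronger inhibition of growth), stand as follows:
Compound 1 `Cc1ccc(NC(=O)c2cccc(C(F)(F)F)c2)cc1N1Cc2cnc(NC3CCCCC3)nc2N(C)C1=O` gives 5220 nM
Compound 2 `Cc1ccc(Nc2ncc3c(n2)N(C2CC2)C(=O)N(c2cc(NC(=O)c4ccc(C)c(C(F)(F)F)c4)ccc2C)C3)cn1` gives 649 nM
Compound 3 `Cc1ccc(Nc2ncc3c(n2)N(c2ccccc2)C(=O)N(c2cc(NC(=O)c4ccc(C)c(C(F)(F)F)c4)ccc2C)C3)cn1` gives 3300 nM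

Compound 1 stands at the high end of these numbers, within the scatter of compound 3 and beyond it from compound 2. Compound 4 `Cc1ccc(NC(=O)c2cccc(C(F)(F)F)c2)cc1N1Cc2cnc(Nc3cnn(C)c3)nc2N(C)C1=O` carries 1-methyl-1H-pyrazol-4-yl in place of cyclohexyl on a nitrogen on an aromatic ring. Among the measured compounds shown here, the one measured step (a 5.1-fold higher number from compound 2 to compound 3 (0.71 log units; beyond the scatter)) lies at another place, so it does not cover this change and offers only a size for a single change. Compound 2 and compound 3 also carry an aromatic ring on that nitrogen, but they differ from compound 1 elsewhere too, and their values disagree. A modest move to a lower number in this assay is therefore expected (a 3.5-fold lower number from compound 1 to compound 4 (0.54 log units; beyond the scatter)). For compound 4 the estimated value is 1500 nM with 300 nM to 6000 nM as its expected range.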

Compound 4, concentration for 50% growth inhibition: 352 nM
The estimate for compound 4 lay 4.3-fold (0.63 log units) above the measured number, within the range that was stated.
By their numbers in this assay, from the lowest: compounds 4 and 2 (each within the scatter of the next); then compounds 3 and 1 (each within the scatter of the next).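

In this assay the change from cyclohexyl to 1-methyl-1H-pyrazol-4-yl gives a 15-fold lower number from compound 1 to compound 4 (1.17 log units; beyond the scatter). Among the compounds shown here, this shows that a single change on a nitrogen on an aromatic ring can produce a large step on the core of compound 1, whereas the only earlier step lay at another place. No measurement shown here explains this step.

Going by these compounds, it remains open whether a phenyl or an unsubstituted pyrazole at this place would give a step of similar size. On these data alone, it also remains open whether a longer chain or a piperidine would retain the lower number.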